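This account rests on a few compounds, and the source may have more. Where it says the series, first, only, none or still open, it means among the compounds named here.

Compound 1 `Cc1ncc([N+](=O)[O-])n1CCSc1nnc(-c2ccccc2)o1` gives 17500 nM in a functional assay on HepG2 cells (Homo sapiens) for cytotoxicity, read by MTT assay, with a stated time of 48 h; a lower number here means a stronger inhibitor, a higher number a weaker inhibitor.
Compound 2 `Cc1ccc(-c2nnc(SCCn3c([N+](=O)[O-])cnc3C)o2)cc1` gives 2200 nM.
Compound 3 `Cc1ncc([N+](=O)[O-])n1CCSc1nnc(-c2ccccc2O)o1` gives 19600 nM.

Compound 2 differs from compound 1 by methyl in place of hydrogen on an aromatic carbon, and that change gave an 8.0-fold lower number from compound 1 to compound 2 (0.90 log units; beyond the scatter). Compound 3 differs from compound 1 by hydroxy in place of hydrogen on an aromatic carbon; the two are within the scatter of each other, a 1.1-fold higher number from compound 1 to compound 3 (0.05 log units; within the scatter). Compound 4 `Cc1cccc(-c2nnc(SCCn3c([N+](=O)[O-])cnc3C)o2)c1O` is not yet measured and differs from compound 3 by methyl in place of hydrogen on an aromatic carbon. This is the same kind of change as from compound 1 to compound 2, but the place is not the same: there the methyl sat para to a large group, here it sits ortho to a hydroxy group and meta to a large group. The earlier step is only a rough guide, so a smaller step is expected, a 2.5-fold lower number from compound 3 to compound 4 (0.39 log units; beyond the scatter). Compound 4 is estimated at 8000 nM, with a likely range from 2500 nM to 25000 nM.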

Compound 4, half-maximal inhibitory concentration: 8700 nM
Beside the measured number, compound 4's estimate is 1.1-fold (0.04 log units) below it; the measured number falls inside the stated range.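

Methyl in place of hydrogen gives a 2.3-fold lower number from compound 3 to compound 4 (0.35 log units; beyond the scatter) in this assay, the same direction as on the core of compound 1 but a different size: the same change on two cores in this assay, an 8.0-fold lower number (0.90 log units; beyond the scatter) from compound 1 to compound 2 and a 2.3-fold lower number (0.35 log units; beyond the scatter) from compound 3 to compound 4, 3.5-fold (0.55 log units) apart, beyond the scatter of two such steps

So the direction held on these two cores, but the size did not carry over, and with the methyl at a different place in each pair, these steps cannot separate the effect of its place from that of the hydroxy group. Replacing 4-methylphenyl with 2-hydroxy-3-methylphenyl gives a 4.0-fold higher number from compound 2 to compound 4 (0.60 log units; beyond the scatter), while replacing phenyl with 2-hydroxy-3-methylphenyl gives a 2.0-fold lower number from compound 1 to compound 4 (0.30 log units; within the scatter).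

Going by these compounds, it remains open how the step would compare with the methyl at the same place on both cores. Also open, on these data alone, is what an ethyl group or an amine would do in the methyl's place.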